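Trading the Methacrylamide Double Bond for a Saturated Isopropyl

This account rests on a few compounds, and the source may have more. Where it says the series, first, only, none or still open, it means among the compounds named here.

Measured so far:
compound 1, `COc1ccc(CNc2cc(OC)c(OC)c(OC)c2)cc1Cl`, 47800 nM
compound 2, `C=C(C)C(=O)N(Cc1ccc(OC)c(O)c1)c1cc(OC)c(OC)c(OC)c1`, 200 nM
compound 3, `COc1cc(NCc2cccc(O)c2)cc(OC)c1OC`, 71300 nM

Of the compounds shown here, three sharing the same trimethoxyphenyl-bearing core have been tested in a functional assay on KYSE-450 cells (Homo sapiens) for inhibition, read by MTT assay, with a stated time of 48 h; a higher number here means a weaker inhibitor, a lower number a stronger inhibitor. Compound 1 gives 47800 nM and compound 3 gives 71300 nM, both of them secondary amines. Compound 2 carries an amide on that nitrogen and gives 200 nM, the lowest of the three numbers; its gaps to compound 1 and to compound 3 both lie well beyond the scatter, so compound 2 stands as the most potent of the set.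

Compound 4, `COc1ccc(CN(C(=O)C(C)C)c2cc(OC)c(OC)c(OC)c2)cc1O`, has not yet been tested in this assay. It differs from compound 2 in one place: isopropyl in place of 1-methylethenyl on a carbonyl carbon. The double bond outside aromatic rings that compound 2 carries is thus gone, while the count of heavy atoms is unchanged. Within the data shown here, no measured pair in this set shows what such a change does, so the expectation rests on compound 2 alone, whose 200 nM is the point of reference.

The author expects compound 4 to be weaker than compound 2, with the step of a 15-fold higher number from compound 2 to compound 4 (1.18 log units; beyond the scatter) lying beyond the scatter. Compound 4 is estimated at 3000 nM, within a range from 500 nM to 20000 nM.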

Compound 4, half-maximal inhibitory concentration: 390 nM
Estimate against measurement, compound 4: 7.7-fold (0.89 log units) above, outside the stated range (below it).
By their numbers in this assay, from the lowest: compounds 2 and 4 (each within the scatter of the next); then compounds 1 and 3 (each within the scatter of the next).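

In this assay, putting isopropyl in place of 1-methylethenyl on a carbonyl carbon gives a 2.0-fold higher number from compound 2 to compound 4 (0.29 log units; within the scatter) and so leaves the two compounds indistinguishable in this read-out. The earlier compounds shown here offered no pair differing in one place, whereas this pair shows that, at this position and in this assay, the double bond outside aromatic rings in compound 2 is not needed for a value in this range, at least when a saturated group with the same count of heavy atoms takes its place. Nothing available explains why compound 2 and compound 4 read alike.

The compounds shown leave open how far this tolerance extends, as a cyclopropyl group, a longer chain such as n-butyl, or a chain ending in an amine on the same carbonyl carbon would test it beyond this single exchange. They also leave open what the carbonyl itself contributes, since compound 1 and compound 3 differ from compound 2 in more than one place and cannot isolate it.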